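The compounds below may be only part of what the source reports. "The series", "measured", "known", "first", "only" and "open" are said of these compounds alone.

Working notes on the series. The shared core is that of compound 1 `CCOC(=O)/C=C/c1cc(Cl)ccc1OC(=O)c1nc(C)c(C)nc1C`, which in a functional assay on EA.hy 926 cells (Homo sapiens) for cytotoxicity, read by MTT assay, with stated times of 24 h and 12 h, tested at 12.5 uM (on this read-out higher numbers stand for a stronger effect at the one concentration tested and lower numbers for a weaker effect), gives 64.9%. Among the compounds with values here, compound 2 `CCOC(=O)/C=C/c1ccccc1OC(=O)c1nc(C)c(C)nc1C` differs from it in one place; in this assay compound 2 gives 9.6%, the lowest of the three numbers so far. Compound 3 `Cc1nc(C)c(C(=O)Oc2ccccc2/C=C/C(=O)O)nc1C` gives 45.7% in this assay. Two steps connect these: a number 55.3 percentage points lower from compound 1 to compound 2 (beyond the scatter), and a number 36.1 percentage points higher from compound 2 to compound 3 (beyond the scatter). Both are large and beyond the scatter, and both leave compound 2 at the bottom.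

Compound 4 `CCOC(=O)/C=C/c1ccc(OC)cc1OC(=O)c1nc(C)c(C)nc1C` is not yet measured. Compared with compound 2 the change is methoxy in place of hydrogen on an aromatic carbon. Within the data shown here, only the step from compound 1 to compound 2 touches a substituent on the same aromatic ring, and it ran downward when a group was taken away; read in reverse it suggests that putting a group onto that ring can move the number upward by a large amount, though the group and its place are not the same here. The step from compound 2 to compound 3 concerns a different part of the molecule and does not bear directly. The expectation for compound 4 is therefore an upward step, a number 20.4 percentage points higher from compound 2 to compound 4 (beyond the scatter), with wide uncertainty. The estimated value for compound 4 in this assay is 30%, within a range from 8% to 60%.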

Compound 4, a percentage reported as activity, at one concentration (the size of the read-out at that concentration, not a potency): -57.6%
Estimate against measurement, compound 4: 87.6 percentage points above; measured number below the stated range.
By their numbers in this assay, from the lowest: compound 4; then compound 2; then compound 3; then compound 1.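

Within the data shown here, with methoxy on an aromatic carbon para to a 2-(ethoxycarbonyl)ethenyl group and meta to a large group, a number 67.2 percentage points lower from compound 2 to compound 4 (beyond the scatter) in this assay and compound 4 gives -57.6% as the only negative number so far. Adding a group to this aromatic ring therefore does not raise the number in every case: adding methoxy lowers it, while the step of a number 55.3 percentage points lower from compound 1 to compound 2 (beyond the scatter) shows that removing chloro from the same ring also lowers it, so the two substituents at their two places push the number in opposite directions. The data at hand offer no measurement that accounts for this reversal or for the negative number.

The compounds shown cannot separate the effect of the group from that of its place, as chloro and methoxy occupy different ring carbons and neither appears at the other's place. Going by these compounds, it also remains open whether a smaller group such as fluoro, or an amine or a hydroxy group, on the carbon bearing methoxy would give a negative number in this assay as well, and whether methoxy would act the same way with the free carboxylic acid of compound 3.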